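This account rests on a few compounds, and the source may have more. Where it says the series, first, only, none or still open, it means among the compounds named here.

Measured compounds:
- Compound 1, `C=CCOc1cc(/C=C\c2cc(OC)c(OC)c(OC)c2)ccc1OC`: 43500 nM
- Compound 2, `C/C=C/COc1cc(/C=C\c2cc(OC)c(OC)c(OC)c2)ccc1OC`: 135000 nM
- Compound 3, `COc1ccc(/C=C/CCCOc2cc(/C=C\c3cc(OC)c(OC)c(OC)c3)ccc2OC)cc1`: 88000 nM

In an ADME assay on HEK293 cells (Homo sapiens) for inhibition, read by MTT assay, with a stated time of 3 days (a higher number here means a weaker inhibitor, a lower number a stronger inhibitor), compound 1 gives the lowest of the three numbers. Its nearest neighbour is compound 3, with a 2.0-fold higher number from compound 1 to compound 3 (0.31 log units; beyond the scatter); the furthest is compound 2, with a 3.1-fold higher number from compound 1 to compound 2 (0.49 log units; beyond the scatter). Between compound 2 and compound 3 there is a 1.5-fold lower number from compound 2 to compound 3 (0.19 log units; within the scatter), so those two cannot be told apart.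

Compound 4, `COc1ccc(/C=C\c2cc(OC)c(OC)c(OC)c2)cc1OCCC/C=C/c1ccc(F)cc1`, has not yet been measured in this assay. It differs from compound 1 as follows: 4-(4-fluorophenyl)but-3-en-1-yl in place of vinyl on a saturated chain carbon bound to an oxygen on an aromatic ring.

Going by the values given here, the step that bears most directly on this change is the one from compound 1 to compound 3, where a longer chain ending in a substituted phenyl ring also replaced vinyl and gave a 2.0-fold higher number from compound 1 to compound 3 (0.31 log units; beyond the scatter), a modest rise. The step from compound 1 to compound 2, a smaller extension, gave a 3.1-fold higher number from compound 1 to compound 2 (0.49 log units; beyond the scatter). Both extensions of the vinyl group on the saturated chain carbon bound to the oxygen therefore raised the number. For compound 4, which again carries a 4-arylbut-3-en-1-yl chain in that place, a modest rise of similar size is expected: a 1.7-fold higher number from compound 1 to compound 4 (0.24 log units; within the scatter). Compound 4 is expected to give 75000 nM, with a range from 30000 nM to 200000 nM.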

Compound 4, half-maximal inhibitory concentration: 115000 nM
Compound 4: the middle estimate sits 1.5-fold (0.19 log units) below what was measured, and the stated range covers the measured number.
By their numbers in this assay, from the lowest: compound 1; then compounds 3, 4 and 2 (each within the scatter of the next).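

In this assay, the 4-(4-fluorophenyl)but-3-en-1-yl chain in place of vinyl on a saturated chain carbon bound to an oxygen on an aromatic ring gives a 2.6-fold higher number from compound 1 to compound 4 (0.42 log units; beyond the scatter) and so adds a third extension at this position that stays clear of compound 1, which now lies beyond the scatter of all three other compounds. The far end of the chain and the size of the group make no readable difference here, since fluoro in place of methoxy on an aromatic carbon gives a 1.3-fold higher number from compound 3 to compound 4 (0.12 log units; within the scatter) and the change from the prop-1-en-1-yl chain to the much larger 4-(4-fluorophenyl)but-3-en-1-yl chain gives a 1.2-fold lower number from compound 2 to compound 4 (0.07 log units; within the scatter), both within the scatter. Nothing measured here accounts for the rise that these extensions share.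

The compounds shown leave open whether any group at this position could give a number lower than that of compound 1, for instance a plain ethyl or a chain ending in an amine or a carboxylic acid. They also leave open how a shorter or longer chain carrying the same aromatic ring, or a saturated chain without the double bond, would read in this assay when set against compound 3 and compound 4.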